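The source may hold more compounds than are shown below. What is called first, only, known or untested is meant among the compounds shown, and "the series" means these compounds.

Working notes on the series. Within the data shown here, in a functional assay on NCI-H460 cells (Homo sapiens) for cytotoxicity, read by MTT assay, with a stated time of 72 h (a higher number here means a weaker inhibitor, a lower number a stronger inhibitor), compound 2 `CCN(CC)CCCNc1nc(-c2ccc(NC(=O)Nc3ccc(C)cc3)cc2)nc2c(Cl)c(Cl)sc12` gives 1240 nM, and compound 1 `CCN(CC)CCCNc1nc(-c2ccc(NC(=O)Nc3ccc(Cl)cc3Cl)cc2)nc2c(Cl)c(Cl)sc12` gives 1170 nM, so the two numbers are indistinguishable; the only measured step, a 1.1-fold higher number from compound 1 to compound 2 (0.03 log units; within the scatter), concerns the aryl on the amide-type nitrogen, not the basic side chain. Compound 3 `CCN(CC)CCNc1nc(-c2ccc(NC(=O)Nc3ccc(C)cc3)cc2)nc2c(Cl)c(Cl)sc12` differs from compound 2 by diethylamino in place of (diethylamino)methyl on a saturated chain carbon, two bonds along the chain from a nitrogen on an aromatic ring. No measured step in this assay touches that chain, so nothing shown bears directly on it; the one step available is within scatter and offers no direction. For compound 3 a number close to compound 2 is therefore expected, 1200 nM with range 500 nM to 3000 nM, meaning an expected step of a 1.0-fold lower number from compound 2 to compound 3 (0.01 log units; within the scatter).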

Compound 3, half-maximal inhibitory concentration: 840 nM
Compound 3: middle estimate off by 1.4-fold (0.15 log units), on the high side, and the stated range covers the measured number.
By their numbers in this assay, from the lowest: compounds 3, 1 and 2 (each within the scatter of the next).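

Among these compounds, with 2-(diethylamino)ethyl in place of 3-(diethylamino)propyl, this assay shows a 1.5-fold lower number from compound 2 to compound 3 (0.17 log units; within the scatter), the first reading on this chain rather than on the aryl. So, with 4-methylphenyl held on the amide-type nitrogen, this change of chain length leaves the number within the scatter, and no direction can be assigned to it. No evidence on hand bears on this result. Still open, going by these compounds, is whether a longer chain such as 4-(diethylamino)butyl, or a carboxylic acid in place of diethylamino, would keep the number in this range. Also open, on these data alone, is whether the same chain step would read alike with the 2,4-dichlorophenyl of compound 1.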